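The source may report more compounds than this note shows. Statements on the series, on what has been measured and on what is new or still open speak of the compounds shown alone.

Two carbamates built on the shared core have been measured in an ADME assay on BEAS-2B cells (Homo sapiens) for cytotoxicity, read by MTT assay, with a stated time of 72 h; on this read-out lower numbers stand for stronger inhibition of growth and higher numbers for weaker inhibition of growth. Compound 1 `COc1ccc(OC(=O)Nc2ccc([Se]C#N)cc2)cc1` gives 48400 nM, and compound 2 `CCCOC(=O)Nc1ccc([Se]C#N)cc1` gives 46300 nM. Compound 2 stands at the smaller of the two numbers, but its gap to compound 1 lies within the scatter, so the two cannot be told apart. Compound 3 `CCOC(=O)Nc1ccc([Se]C#N)cc1` differs from compound 2 in one place: hydrogen in place of methyl on a saturated chain carbon, two bonds along the chain from an oxygen next to a carbonyl group. For so small a change no step beyond the scatter is expected in this assay in either direction, and compound 3 is therefore estimated at 47000 nM, between 23000 nM and 95000 nM, which amounts to an expected step of a 1.0-fold higher number from compound 2 to compound 3 (0.01 log units; within the scatter).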

Compound 3, concentration for total growth inhibition: 46900 nM
Compound 3: middle estimate off by 1.0-fold (0.00 log units), on the high side, and the stated range covers the measured number.
By their numbers in this assay, from the lowest: compounds 2, 3 and 1 (each within the scatter of the next).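

In this assay, going by these compounds alone, hydrogen in place of methyl on a saturated chain carbon, two bonds along the chain from an oxygen next to a carbonyl group, gives a 1.0-fold higher number from compound 2 to compound 3 (0.01 log units; within the scatter) and so this is the first comparison here that isolates a single change. Going from propoxy to ethoxy leaves the number within the scatter, so this methyl can be lost with no readable effect. No measurement at hand offers an explanation for this result. Going by these compounds, whether a longer chain such as butyl, or an amine or a carboxylic acid on this chain, would shift the number beyond the scatter stays open.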